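The compounds below may be only part of what the source reports. "The series", "measured", "known", "first", "only" and "open" are said of these compounds alone.

Compound 1 `C=CCn1c(=O)/c(=C\c2cccc(Cl)c2)[nH]c(=O)/c1=C\c1ccccc1OC`: 2700 nM in a functional assay on K562 cells (Homo sapiens) for cytotoxicity, read by CCK-8 assay, with a stated time of 72 h; a higher number here means a weaker inhibitor, a lower number a stronger inhibitor
Compound 2 `C=CCn1c(=O)/c(=C\c2ccc(Cl)c(Cl)c2)[nH]c(=O)/c1=C\c1ccccc1OC`: "not active" (no number reported) in this assay
Compound 3 `C=CCn1c(=O)/c(=C\c2cc(Br)ccc2F)[nH]c(=O)/c1=C\c1ccccc1OC`: to be measured in this assay

Among the measured compounds shown here, compound 1 gives 2700 nM in this assay and is the only compound of this set with a number. For the measured compounds named here, compound 2 is reported as "not active" (no number reported) in this assay, so no number places it on the scale, and no step from it to another compound can be computed. Compound 3 differs from compound 2 in one place: 5-bromo-2-fluorophenyl in place of 3,4-dichlorophenyl on a double-bonded chain carbon bound to an aromatic carbon. Going by the values given here, with compound 2 giving no number, the size and direction of the step from compound 2 to compound 3 cannot be set from the data; the one numbered anchor is compound 1 at 2700 nM, and compound 3 shares its core. Compound 3 is therefore expected to be a weak inhibitor, estimated at 6000 nM with a range from 1500 nM to 25000 nM, and it may again be reported only as not active.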

Compound 3, half-maximal inhibitory concentration: 5100 nM
Beside the measured number, compound 3's estimate is 1.2-fold (0.07 log units) above it, within the range that was stated.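

In this assay, putting 5-bromo-2-fluorophenyl in place of 3-chlorophenyl on a double-bonded chain carbon bound to an aromatic carbon gives a 1.9-fold higher number from compound 1 to compound 3 (0.28 log units; within the scatter), so this change leaves compound 1 and compound 3 indistinguishable. Compound 3 also shows that a phenyl ring with two halogen atoms at this place can give a measurable value, although compound 2, which also carries two halogen atoms, goes against any general rule and its steps cannot be read. Nothing among the data shown accounts for the difference between compound 2 and compound 3.

The compounds shown leave open whether activity at this place depends on where the halogen atoms stand. They also leave open how a phenyl ring carrying an amine or a carboxylic acid would behave here.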